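This account rests on a few compounds, and the source may have more. Where it says the series, first, only, none or still open, it means among the compounds named here.

In a functional assay on A549 cells (Homo sapiens) for cytotoxicity, read by MTT assay, with a stated time of 48 h (a higher number here means a weaker inhibitor, a lower number a stronger inhibitor), compound 1 `COc1cc(-c2nnc3n2NC(c2ccco2)C(C(=O)c2cccs2)S3)cc(OC)c1OC` gives 78700 nM. Compound 2 `COc1cc(-c2nnc3n2NC(c2cccs2)C(C(=O)c2ccc(F)cc2)S3)cc(OC)c1OC` gives 45000 nM in this assay, and the two numbers sit within the scatter of each other. Compound 3 `COc1cc(C(=O)C2Sc3nnc(-c4cc(OC)c(OC)c(OC)c4)n3NC2c2cccs2)cc(OC)c1OC` reaches only the limit > 100000 nM in this assay. Among the measured compounds shown here, that limit, (the limit of > 100000 nM in this assay, at which 1 of the 3 values shown sits), is the end point of the one measured step, an at least 2.2-fold higher number from compound 2 to compound 3 (0.34 log units; beyond the scatter), a swap of the aryl group on the carbonyl carbon. Compound 4 `COc1ccc(C(=O)C2Sc3nnc(-c4cc(OC)c(OC)c(OC)c4)n3NC2c2ccco2)cc1` differs from compound 1 by 4-methoxyphenyl in place of thiophen-2-yl on a carbonyl carbon, again a swap of the aryl group on the carbonyl carbon, though a different one. For the measured compounds named here, since the one comparable step was at least modest and upward, compound 4 is expected to give 85000 nM, between 35000 nM and 200000 nM, a step of a 1.1-fold higher number from compound 1 to compound 4 (0.03 log units; within the scatter).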

Compound 4, half-maximal inhibitory concentration: > 100000 nM
Compound 4 ended at the assay's limit; the forecaster's own chance of this, stated with the estimate: 35%; middle value at least 1.1-fold (0.07 log units) from the limit.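

Compound 4 sits at a limit of the assay, > 100000 nM in this assay. The change gives an at least 1.2-fold higher number from compound 1 to compound 4 (0.10 log units; that floor lies within the scatter), so thiophen-2-yl and 4-methoxyphenyl on this carbonyl carbon cannot be told apart by a firm step, though the replacement brings no gain. Both compounds with a methoxy-bearing phenyl on this carbonyl carbon, compound 3 and compound 4, end at the same limit: the limit of > 100000 nM in this assay, at which 2 of the 4 values shown sit.

Going by these compounds, the true number for compound 4 remains open. So does whether an aminophenyl or a carboxyphenyl group on this carbonyl carbon would give a lower number.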